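Halogen exchange on the fused core: chloro, fluoro, bromo

The compounds below may be only part of what the source reports. "The series", "measured", "known", "first", "only" and "open" are said of these compounds alone.

In an assay on isolated protein for inhibition of protein kinase C zeta type (Homo sapiens), read by 33P incorporation, tested at 50 uM (on this read-out higher numbers stand for a stronger effect at the one concentration tested and lower numbers for a weaker effect), compound 1 `O=C(O)CC(Cc1nc2cc(Cl)ccc2[nH]1)c1ccc(Cl)cc1` gives 0%. Compound 2 `O=C(O)CC(Cc1nc2cc(F)ccc2[nH]1)c1ccc(Cl)cc1` carries fluoro in place of chloro on an aromatic carbon and in this assay compound 2 gives 0%. The step of no change at the digits printed from compound 1 to compound 2 (within the scatter) lies within the scatter, so compound 2 stands level with compound 1 on the numbers shown, both without measurable inhibition at the single concentration.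

Compound 3 `O=C(O)CC(Cc1nc2cc(Br)ccc2[nH]1)c1ccc(Cl)cc1` differs from compound 2 by bromo in place of fluoro on an aromatic carbon. Within the data shown here, the only measured step that bears on this change is no change at the digits printed from compound 1 to compound 2 (within the scatter), a halogen exchange on an aromatic carbon of the six-membered ring of the fused system, which produced no change beyond the scatter. With both measured compounds at zero, no step beyond the scatter is expected in this assay for compound 3. Compound 3 is expected to give 0%, with a range from -8% to 10%. The expected step is therefore no change at the digits printed from compound 2 to compound 3 (within the scatter).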

Compound 3, a percentage reported as inhibition, at one concentration (the size of the read-out at that concentration, not a potency): 25%
Beside the measured number, compound 3's estimate is 25 percentage points below it; measured number outside the range, above it.
By their numbers in this assay, from the lowest: compounds 1 and 2 (each within the scatter of the next); then compound 3.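

At this aromatic carbon of the shared core, the choice of halogen can register in this assay: bromo in place of fluoro gives a number 25 percentage points higher from compound 2 to compound 3 (beyond the scatter) and bromo in place of chloro gives a number 25 percentage points higher from compound 1 to compound 3 (beyond the scatter). The flat result from the earlier pair therefore holds for chloro and fluoro only and does not extend to every halogen at this position. No available measurement bears on what lies behind this difference.

From the compounds shown here alone, whether iodo or a non-halogen such as trifluoromethyl or nitrile at the same carbon would continue the rise remains open, as does whether the carboxylic acid is needed for the effect seen with bromo. The read-out comes from one concentration, so it shows only the stronger effect of compound 3 at that concentration.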